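From a Hydroxy to a Hydroxypropylamino Group

This account rests on a few compounds, and the source may have more. Where it says the series, first, only, none or still open, it means among the compounds named here.

Compound 1 `CNc1cc(Oc2ccc(NC(=O)Nc3ccccc3)cc2)ncn1` gives 6300 nM in an assay on isolated protein for inhibition of serine/threonine-protein kinase TNNI3K (Homo sapiens); a higher number here means a weaker inhibitor, a lower number a stronger inhibitor. Compound 2 `O=C(Nc1ccc(Oc2cc(O)ncn2)cc1)Nc1cccc(C(F)(F)F)c1` gives 3200 nM in this assay, the lower of the two plain numbers, yet its gap to compound 1 lies within the scatter, so the two cannot be told apart. Compound 3 `CNc1cc(Oc2ccc(NC(=O)Nc3cccc(C(F)(F)F)c3)cc2C)ncn1` reaches <= 10 nM in this assay, which is a limit of the assay rather than a number (the limit of <= 10 nM in this assay, at which 1 of the 3 values shown sits). Compound 4 `C[C@H](O)CNc1cc(Oc2ccc(NC(=O)Nc3cccc(C(F)(F)F)c3)cc2)ncn1` has not been measured; it differs from compound 2 by (2-hydroxypropyl)amino in place of hydroxy on an aromatic carbon. Among the compounds with values here, no pair of measured compounds isolates this change, so the expectation rests on the whole set. A sizeable fall in number is expected for the step of an 11-fold lower number from compound 2 to compound 4 (1.03 log units; beyond the scatter). Compound 4 is estimated at 300 nM in this assay, with a range from 60 nM to 1500 nM.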

Compound 4, half-maximal inhibitory concentration: 32 nM
Compound 4: the middle estimate sits 9.4-fold (0.97 log units) above what was measured, outside the stated range (below it).
By their numbers in this assay, from the lowest: compound 4; then compounds 2 and 1 (each within the scatter of the next). At a limit, below all of these: compound 3.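

In this assay, (2-hydroxypropyl)amino in place of hydroxy on this aromatic carbon, next to the ring nitrogen, gives a 100-fold lower number from compound 2 to compound 4 (2.00 log units; beyond the scatter). This is the first step shown at this position, and it reveals that the larger group is accepted there and that this one change lowers the number strongly. Nothing shown explains this gain.

From the compounds shown here alone, whether the hydroxy at the end of the chain contributes remains open. A plain propylamino chain, or a longer chain ending in an amine or a carboxylic acid, would address this.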